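Compound 3: a shorter ether chain on the shared core

The source may hold more compounds than are shown below. What is called first, only, known or untested is meant among the compounds shown, and "the series" means these compounds.

Compound 1 `O=c1c(-c2ccc(F)cc2)c[nH]c2ccnc(Nc3ccc(Oc4ccnc5cc(O)ccc45)c(F)c3)c12` gives 0.893 h
Compound 2 `COC(C)(C)COc1ccc2c(Oc3ccc(Nc4nccc5[nH]cc(-c6ccc(F)cc6)c(=O)c45)cc3F)ccnc2c1` gives 1.45 h

Among the compounds with values here, in an ADME assay on microsomes from liver (Rattus norvegicus) for metabolic stability (a lower number here means that the compound disappears faster, a higher number that the compound lasts longer), compound 2, at 1.45 h, cannot be told apart from compound 1, the only other compound measured so far. Compound 3 `COCCOc1ccc2c(Oc3ccc(Nc4nccc5[nH]cc(-c6ccc(F)cc6)c(=O)c45)cc3F)ccnc2c1` has not yet been measured. It differs from compound 2 by one change (methoxymethyl in place of 1-methoxy-1-methylethyl on a saturated chain carbon bound to an oxygen on an aromatic ring): methoxymethyl in place of 1-methoxy-1-methylethyl on a saturated chain carbon bound to an oxygen on an aromatic ring. Within the data shown here, only one measured step bears on this change, namely a 1.6-fold higher number from compound 1 to compound 2 (0.21 log units; within the scatter), where the entire 2-methoxy-2-methylpropyl replaced hydrogen. With so small a step on record, no change beyond the scatter is expected in this assay for 2-methoxyethyl in place of 2-methoxy-2-methylpropyl. The expected step is a 1.2-fold lower number from compound 2 to compound 3 (0.08 log units; within the scatter), with its direction uncertain. Compound 3 is estimated at 1.2 h (range 0.65 h to 2.2 h).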

Compound 3, half-life: 1.73 h
Beside the measured number, compound 3's estimate is 1.4-fold (0.16 log units) below it; low and high end bracket the measured number.
By their numbers in this assay, from the lowest: compounds 1, 2 and 3 (each within the scatter of the next).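

In this assay, shortening the chain on the oxygen on the aromatic ring, with methoxymethyl in place of 1-methoxy-1-methylethyl, gives a 1.2-fold higher number from compound 2 to compound 3 (0.08 log units; within the scatter), so going from 5 heavy atoms to 3 at this place leaves the half-life unresolved from that of the longer ether. With 2-methoxyethyl in place of hydrogen on that oxygen, the result is a 1.9-fold higher number from compound 1 to compound 3 (0.29 log units; within the scatter), and thus neither ether chain shown has moved the half-life beyond the scatter from that of the compound bearing only hydrogen there. No measurement shown gives a reason for these numbers.

What the compounds leave open is whether any group at this place can shift the half-life beyond the scatter. A terminal amine, a carboxylic acid or a longer chain in place of the methoxy end could answer that.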